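The source may report more compounds than this note shows. Statements on the series, on what has been measured and on what is new or still open speak of the compounds shown alone.

Working notes, series in a functional assay on MDA-MB-231 cells (Homo sapiens) for inhibition, read by MTT assay, with a stated time of 48 h; on this read-out lower numbers stand for stronger inhibition of growth and higher numbers for weaker inhibition of growth:

- compound 1 `Oc1ccc(Nc2ncnc3ccc(NC(=S)NCc4ccccc4)cc23)cc1`: 27000 nM
- compound 2 `S=C(Nc1ccccc1)Nc1ccc2ncnc(Nc3cccc(Br)c3)c2c1`: 10000 nM

Compound 2 holds the lower of the two numbers in this assay, at 10000 nM. Among the compounds with values here, its only neighbour, compound 1, has the higher number at 27000 nM, and this gap lies beyond the scatter. Next is compound 3 `NS(=O)(=O)c1ccc(NC(=S)Nc2ccc3ncnc(Nc4cccc(Br)c4)c3c2)cc1`, which has sulfamoyl in place of hydrogen on an aromatic carbon, para to a large group, so that phenyl becomes 4-sulfamoylphenyl: sulfamoyl in place of hydrogen on an aromatic carbon. Within the data shown here, no measured pair differs in one place only, so the data give no direct size for such a change. Among the measured compounds shown here, the sole guide is the narrow spread of the two values so far. The expected change is a 1.3-fold lower number from compound 2 to compound 3 (0.10 log units; within the scatter), with no step beyond the scatter anticipated in either direction. For compound 3 the estimated value is 8000 nM, with an expected range of 2500 nM to 25000 nM.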

Compound 3, concentration for 50% growth inhibition: > 30000 nM
Compound 3: only a limit was reported; the forecaster's own chance of this, stated with the estimate: 8%; middle value at least 3.7-fold (0.57 log units) away from the limit.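

Within the data shown here, this is the first step that changes one place only, and it gives a direct reading where the earlier compounds gave none: phenyl to 4-sulfamoylphenyl, with sulfamoyl in place of hydrogen on an aromatic carbon, para to a large group, gives an at least 3.0-fold higher number from compound 2 to compound 3 (0.47 log units; beyond the scatter). At this position, then, the change weakens growth inhibition in this assay rather than leaving it unchanged. Compound 3 gives > 30000 nM, which is a limit and not a number, so the step has a lower bound but no measured size: the limit of > 30000 nM in this assay, at which 1 of the 3 values shown sits.

The compounds shown leave open whether this step belongs to sulfamoyl alone or would also appear with another group at this place, such as an amine or a carboxylic acid. Also open, as far as these compounds go, is whether the same change would act alike on the core of compound 1.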